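The source may report more compounds than this note shows. Statements on the series, on what has been measured and on what is new or still open speak of the compounds shown alone.

Measured so far:
compound 1 `Cc1cc(C(N)=O)nn1Cc1cc(Cl)ccc1OCC(C)C` — 126 nM
compound 2 `CC(=O)Nc1cc(C)n(Cc2cc(Cl)ccc2OCc2ccccc2)n1` — 316 nM

Both were tested in an assay on CHO-K1 cells for displacement of a labelled ligand from prostaglandin E2 receptor EP1 subtype (Homo sapiens); on this read-out lower numbers stand for stronger inhibition and higher numbers for weaker inhibition. Of the two numbers, compound 2 has the higher one, so it is the weaker binder of the pair; compound 1 gives the lower number, and the gap between them is wider than repeated measurements usually scatter. Compound 3 `COC(=O)Nc1cc(C)n(Cc2cc(Cl)ccc2OCc2ccccc2)n1` has not been measured yet. It is built from compound 2 by a single change: methoxy in place of methyl on a carbonyl carbon. The carbonyl carbon keeps its amide-type nitrogen as its other neighbour; only the group on its far side is swapped. Among the measured compounds shown here, no measured pair shows what such a swap does here, so the expectation rests on how little of the molecule changes. The step of a 1.1-fold lower number from compound 2 to compound 3 (0.02 log units; within the scatter) is expected to be small, none beyond the scatter. Compound 3 is therefore expected to give roughly 300 nM in this assay, likely between 120 nM and 800 nM.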

Compound 3, half-maximal inhibitory concentration: 200 nM
Compound 3: the middle estimate sits 1.5-fold (0.18 log units) above what was measured; measured number inside the range.
By their numbers in this assay, from the lowest: compounds 1, 3 and 2 (each within the scatter of the next, the first and the last beyond it).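

In this assay, putting methoxy in place of methyl on a carbonyl carbon gives a 1.6-fold lower number from compound 2 to compound 3 (0.20 log units; within the scatter). This first measured pair at this position therefore does not separate the acetamido form from the (methoxycarbonyl)amino form, even though methoxy brings an added oxygen and one more hydrogen-bond acceptor by count. Nothing in the available data explains why the two forms read alike.

Still open, from the compounds shown here alone, is whether a longer chain on the same carbonyl carbon, such as ethoxy or benzyloxy, or an amine in place of the methoxy would keep the number in this range. Going by these compounds, it is also open whether the same swap would read alike in a compound carrying a different ether chain on the shared core.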